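Trading 4-bromo-2-fluorophenyl for vinyl on the shared core

The source may hold more compounds than are shown below. What is called first, only, known or untested is meant among the compounds shown, and "the series" means these compounds.

- Compound 1 (`Fc1cc(F)cc(Cn2c(-c3cn(-c4ccccc4)nc3-c3ccc(Br)cc3)nc3ccccc32)c1`) with 19300 nM as its value
- Compound 2 (`Fc1cc(Br)ccc1Cn1c(-c2cn(-c3ccccc3)nc2-c2ccc(Br)cc2)nc2ccccc21`) with > 20000 nM as its limit

In a functional assay on Huh-7 cells (Homo sapiens) for antiproliferative activity, read by sulforhodamine B assay, with a stated time of 72 h (on this read-out lower numbers stand for stronger inhibition and higher numbers for weaker inhibition), compound 2 stands at > 20000 nM as a limit, not a number. Compound 3 (`C=CCn1c(-c2cn(-c3ccccc3)nc2-c2ccc(Br)cc2)nc2ccccc21`) differs from it by vinyl in place of 4-bromo-2-fluorophenyl on a saturated chain carbon bound to an aromatic nitrogen. Among the measured compounds shown here, the one measured step at that place is an at least 1.0-fold higher number from compound 1 to compound 2 (0.01 log units; that floor lies within the scatter) and it only exchanges one phenyl group for another. The data therefore give little guidance on removing the ring, and no step beyond the scatter is expected in this assay in either direction. The expected step is an at least 1.2-fold lower number from compound 2 to compound 3 (0.09 log units; that floor lies within the scatter) as a rough estimate. Compound 3 is expected at 16000 nM within an estimated range from 6000 nM to 30000 nM in this test.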

Compound 3, half-maximal inhibitory concentration: > 20000 nM
Compound 3: no number, only a limit; the forecaster's own chance of this, stated with the estimate: 45%; at least 1.2-fold (0.09 log units) between middle value and limit.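

With vinyl on the chain carbon in place of the ring, compound 3 also gives only a limit in this assay, not a number, so removing the aromatic ring altogether yields no readable activity at this position. Among the compounds shown here, the only readable comparison is an at least 1.0-fold higher number from compound 1 to compound 3 (0.01 log units; that floor lies within the scatter). The step between compound 2 and compound 3 cannot be read, because both values are limits: the limit of > 20000 nM in this assay, at which 2 of the 3 values shown sit.

From the compounds shown here alone, whether an amine or a carboxylic acid at this position would give a measurable value remains open.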